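A few compounds are considered here, and "the series" means these few. Any claim that something is new, unique, unknown or untested is made for them only; others in the source may bear on it.

Compound 1 `O=C1NC(=S)S/C1=C\N1N=C(c2ccc(Cl)cc2)CC1c1ccc(Cl)cc1`: > 10000 nM
Compound 2 `CC(=O)Oc1ccc(N2C(=O)/C(=C/N3N=C(c4ccc(Cl)cc4)CC3c3ccc(Cl)cc3)SC2=S)cc1`: > 10000 nM

In a functional assay on HL-60 cells (Homo sapiens) for antiproliferative activity, read by MTT assay, with a stated time of 72 h (a lower number here means a stronger inhibitor, a higher number a weaker inhibitor), compound 1 shows only a limit of the assay, not a number. Compound 2 likewise shows only a limit in this assay. The step that the two limits leave unreadable from compound 1 to compound 2 is therefore unreadable, because both values sit at the limit of > 10000 nM in this assay, at which 2 of the 2 values shown sit. Compound 3 `O=C1NC(=S)S/C1=C\N1N=C(c2ccc3ccccc3c2)CC1c1ccc(Cl)cc1` is still unmeasured; its difference from compound 1 is naphthalen-2-yl in place of 4-chlorophenyl on a carbon with a double bond to nitrogen. Within the data shown here, no measured step touches this position, so the data give no size or direction for this change. Compound 3 is expected to give 15000 nM, with a range from 4000 nM to 60000 nM. The expected step is a step that the limit leaves unreadable from compound 1 to compound 3.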

Compound 3, half-maximal inhibitory concentration: 400 nM
Compound 3: middle estimate off by 38-fold (1.57 log units), on the high side; the whole stated range lies above it.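

In this assay, naphthalen-2-yl in place of 4-chlorophenyl on the carbon with a double bond to nitrogen gives an at least 25-fold lower number from compound 1 to compound 3 (1.39 log units; beyond the scatter), so this position can strongly change the read-out. As far as these compounds go, compound 1 gives only a limit, > 10000 nM, so the true size of this step stays unknown. The step from compound 1 to compound 2 cannot be read, which makes this the first change here with a readable size: the limit of > 10000 nM in this assay, at which 2 of the 3 values shown sit.

From the compounds shown here alone, whether the second aromatic ring of naphthalen-2-yl is what matters remains open, since unsubstituted phenyl or 4-methoxyphenyl at this position could separate ring size from loss of the chlorine. Also open, going by these compounds, is whether naphthalen-2-yl keeps its effect alongside the 4-acetoxyphenyl group on the ring nitrogen.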